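The source may hold more compounds than are shown below. What is called first, only, known or untested is meant among the compounds shown, and "the series" means these compounds.

Measured so far in a functional assay on MV4-11 cells (Homo sapiens) for inhibition, with a stated time of 120 h, tested at 10 uM; on this read-out higher numbers stand for more inhibition at the one concentration tested (going by the name of the read-out) and lower numbers for less inhibition:
compound 1 `Cc1n[nH]c2ccc(-c3nc4cnc(N5CCN(C)CC5)cn4c3Nc3ccccc3F)cc12` gives 0%
compound 2 `Cc1n[nH]c2ccc(-c3nc4cnc(N5CCN(C)CC5)cn4c3Nc3cccc(Cl)c3)cc12` gives 0%
compound 3 `Cc1n[nH]c2ccc(-c3nc4cnc(N5CCN(C)CC5)cn4c3Nc3ccc(Cl)cc3)cc12` gives 83.7%

Within the data shown here, compound 2 sits level with compound 1, the two together the lowest of the three numbers; the only step that separates compound 2 from the rest is a number 83.7 percentage points higher from compound 2 to compound 3 (beyond the scatter). Compound 4 `COc1ccc(Nc2c(-c3ccc4[nH]nc(C)c4c3)nc3cnc(N4CCN(C)CC4)cn23)cc1` carries the change (4-methoxyphenyl in place of 3-chlorophenyl on a nitrogen on an aromatic ring). Among the measured compounds shown here, the steps that bear on it are a number 83.7 percentage points higher from compound 2 to compound 3 (beyond the scatter) and a number 83.7 percentage points higher from compound 1 to compound 3 (beyond the scatter), both large and upward, set against no change at the digits printed from compound 1 to compound 2 (within the scatter). Every rise seen so far came with a 4-chlorophenyl, and no 4-methoxyphenyl has been measured, so the size of any rise is open. The step expected in this assay is a number 55 percentage points higher from compound 2 to compound 4 (beyond the scatter), upward and beyond the scatter, though with wide uncertainty. The estimate for compound 4 is 55%, range 10% to 95%.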

Compound 4, a percentage reported as inhibition, at one concentration (the size of the read-out at that concentration, not a potency): 3.32%
The estimate for compound 4 lay 51.7 percentage points above the measured number; measured number below the stated range.
By their numbers in this assay, from the lowest: compounds 1, 2 and 4 (each within the scatter of the next); then compound 3.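

In this assay, methoxy in place of chloro on an aromatic carbon gives a number 80.4 percentage points lower from compound 3 to compound 4 (beyond the scatter), so the high number of compound 3 does not carry over to the 4-methoxyphenyl. With a number 3.3 percentage points higher from compound 2 to compound 4 (within the scatter) and a number 3.3 percentage points higher from compound 1 to compound 4 (within the scatter), compound 4 stands level with the two low compounds, leaving compound 3 alone at the high end. Nothing available explains this difference between chloro and methoxy.

Open, from the compounds shown here alone, is whether bromo, methyl or an amine on that same aromatic carbon would follow chloro or methoxy.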